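This account rests on a few compounds, and the source may have more. Where it says the series, first, only, none or still open, it means among the compounds named here.

Measured so far in a functional assay on A-375 cells (Homo sapiens) for antiproliferative activity, read by CCK-8 assay, with a stated time of 72 h, tested at 8 uM; a lower number here means a weaker effect, a higher number a stronger effect of the compound at the concentration tested:

- compound 1 `Nc1ccccc1NC(=O)c1ccc(CSC(=S)N2CCN(Cc3ccccn3)CC2)cc1`: 82.4%
- compound 2 `Nc1ccccc1NC(=O)c1ccc(CSC(=S)N2CCN(C(c3ccccc3)c3ccccc3)CC2)cc1`: 8.4%
- compound 3 `Nc1ccccc1NC(=O)c1ccc(CSC(=S)N2CCc3ccccc32)cc1`: 85.4%

Compound 3 gives the highest number of the three in this assay, but its gap to compound 1 lies within the scatter, so the two cannot be ordered against each other. For the measured compounds named here, compound 2 stands far lower, beyond the scatter, and is the only member of the set with a weak read-out; its 1,1-diphenylmethyl-bearing piperazine is the one large, two-ring substituent on the thiocarbonyl carbon.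

Compound 4 `CC1CCCCN1C(=S)SCc1ccc(C(=O)Nc2ccccc2N)cc1` is not yet measured. It differs from compound 3 in one place: 2-methylpiperidin-1-yl in place of 2,3-dihydro-1H-indol-1-yl on a thiocarbonyl carbon. Both groups are single small rings on the same thiocarbonyl carbon, with no donors or acceptors counted, and the two well-performing compounds, compound 1 and compound 3, both carry comparably sized amine rings there. Going by the values given here, no measured pair shows this particular exchange, so the expected step from compound 3 to compound 4 is small, at most a modest drop and possibly none beyond the scatter: a number 11.4 percentage points lower from compound 3 to compound 4 (beyond the scatter). For compound 4 the estimate in this assay is 74%, within a range from 50% to 92%.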

Compound 4, a percentage reported as inhibition, at one concentration (the size of the read-out at that concentration, not a potency): 85.2%
Compound 4: middle estimate off by 11.2 percentage points, on the low side, and the stated range covers the measured number.
By their numbers in this assay, from the lowest: compound 2; then compounds 1, 4 and 3 (each within the scatter of the next).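

In this assay, for the compounds shown here, placing 2-methylpiperidin-1-yl in place of 2,3-dihydro-1H-indol-1-yl on a thiocarbonyl carbon gives a number 0.2 percentage points lower from compound 3 to compound 4 (within the scatter) and this is the first comparison that changes a single place. For this pair, the six-membered aromatic ring of the leaving group is not required to keep the read-out at the concentration tested, since a single six-membered non-aromatic ring with fewer heavy atoms gives a result within the scatter. Nothing measured here bears on why the read-out holds across this exchange.

On these data alone, whether the methyl group of 2-methylpiperidin-1-yl contributes remains open, as does the outcome with unsubstituted piperidine, morpholine or an open-chain amine such as diethylamine at this position. A reading at one concentration also leaves open whether compound 3 and compound 4 would separate across a range of concentrations.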